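The source may report more compounds than this note shows. Statements on the series, on what has been measured and on what is new or still open speak of the compounds shown alone.

Working notes on the series. Among the compounds with values here, the first two compounds of the set, compound 1, `CCOC(=O)C1=C(C)NC(CO)=C(C(=O)OCC)C1c1cccc([N+](=O)[O-])c1`, and compound 2, `C=CCOC(=O)C1=C(C)NC(C)=C(C(=O)OC)C1c1cccc([N+](=O)[O-])c1`, share a core and a nitrophenyl group and differ in several places, so no single step can be read between them. In a functional assay on HEK293 cells for antagonist activity at Voltage-dependent L-type calcium channel subunit alpha-1D (Rattus norvegicus), read by FLIPR (a lower number here means a stronger inhibitor, a higher number a weaker inhibitor), compound 1 gives 45 nM and compound 2 gives 15 nM. Compound 2 thus stands at the lowest of the two numbers on record, with compound 1 the nearest, beyond the scatter.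

The next compound, `COC(=O)C1=C(C)NC(C)=C(C(=O)OCCC(C)c2ccccc2)C1c1cccc([N+](=O)[O-])c1` (compound 3), is not yet measured. It differs from compound 2 in one place: 2-phenylpropyl in place of vinyl on a saturated chain carbon bound to an oxygen next to a carbonyl group. Within the data shown here, no measured pair in the set covers a change of this kind, so the size of the step can only be guessed. The expectation is a step from compound 2 to compound 3 of a 1.3-fold lower number from compound 2 to compound 3 (0.10 log units; within the scatter) in this assay, that is, none clearly beyond the scatter. For compound 3 the estimate in this assay is 12 nM, with a range from 4 nM to 40 nM.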

Compound 3, half-maximal inhibitory concentration: 11 nM
Estimate against measurement, compound 3: 1.1-fold (0.04 log units) above; the range from low to high includes it.
By their numbers in this assay, from the lowest: compounds 3 and 2 (each within the scatter of the next); then compound 1.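

In this assay the change to 2-phenylpropyl in place of vinyl on a saturated chain carbon bound to an oxygen next to a carbonyl group reads as a 1.4-fold lower number from compound 2 to compound 3 (0.13 log units; within the scatter), so the two compounds cannot be told apart. This position therefore accepts a group carrying a six-membered aromatic ring of carbon only with no loss beyond the scatter, something compounds 1 and 2, which differ in several places, could not show. This holds for this one pair only, and nothing available on these compounds accounts for the result.

Going by these compounds, whether the aromatic ring or the chain matters here stays open, since a plain longer alkyl chain on this carbon would be needed to separate them. Also open, on these data alone, is how this position responds to an amine or a carboxylic acid in place of 2-phenylpropyl.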